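This account rests on a few compounds, and the source may have more. Where it says the series, first, only, none or still open, it means among the compounds named here.

Measured so far in an ADME assay on J774 cells (Mus musculus) for cytotoxicity, read by MTT assay, with a stated time of 48 h, tested at 150 ug/mL; on this read-out lower numbers stand for a stronger effect and higher numbers for a weaker effect at the one concentration tested:
compound 1 `O=C(N/N=C/c1ccccc1)c1cnccn1`: 100%
compound 2 `O=C(N/N=C/c1ccccc1F)c1cnccn1`: 81%
compound 3 `COc1ccccc1/C=N/NC(=O)c1cnccn1`: 97%

Compound 3 stands second highest of the three numbers. Its nearest neighbour is compound 1, the step being a number 3 percentage points lower from compound 1 to compound 3 (within the scatter). Its furthest neighbour is compound 2, the step being a number 16 percentage points higher from compound 2 to compound 3 (beyond the scatter).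

Compound 4 `N#Cc1ccccc1/C=N/NC(=O)c1cnccn1` differs from compound 3 in one place: cyano in place of methoxy on an aromatic carbon. Among the measured compounds shown here, three measured steps touch the same position of the shared core. The fluoro for hydrogen step gave a number 19 percentage points lower from compound 1 to compound 2 (beyond the scatter). The methoxy for hydrogen step gave a number 3 percentage points lower from compound 1 to compound 3 (within the scatter). The methoxy for fluoro step gave a number 16 percentage points higher from compound 2 to compound 3 (beyond the scatter). For the measured compounds named here, no measured step introduces cyano, so the expectation rests on the spread of the three known substituents, which is modest overall. A step in this assay for compound 4 of a number 7 percentage points lower from compound 3 to compound 4 (within the scatter) is expected, downward by a small margin and possibly within the scatter. Compound 4 is therefore estimated at 90% in this assay, with a range from 72% to 100%.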

Compound 4, a percentage reported as activity, at one concentration (the size of the read-out at that concentration, not a potency): 70%
The estimate for compound 4 lay 20 percentage points above the measured number, and the stated range ends above it.
By their numbers in this assay, from the lowest: compound 4; then compound 2; then compounds 3 and 1 (each within the scatter of the next).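

In this assay, among the compounds shown here, cyano is the first group at this position to take the number below that of the fluoro group, with a number 11 percentage points lower from compound 2 to compound 4 (beyond the scatter), so fluoro no longer marks the low end of the set. Methoxy and cyano match in the counts of heavy atoms and hydrogen-bond acceptors, yet exchanging them gives a number 27 percentage points lower from compound 3 to compound 4 (beyond the scatter), and replacing hydrogen with cyano gives a number 30 percentage points lower from compound 1 to compound 4 (beyond the scatter), the largest step seen here so far. No measured evidence bears on what sets compound 4 apart.

From the compounds shown here alone, how an amine, a carboxylic acid or a longer chain would read at this position remains open. The compounds shown also leave open whether cyano would give a similar step elsewhere on the aromatic ring, and a single concentration gives no potency.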